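Swapping phenylsulfanyl for piperidin-1-yl in a mouse assay

A few compounds are considered here, and "the series" means these few. Any claim that something is new, unique, unknown or untested is made for them only; others in the source may bear on it.

Values so far in a functional assay on the whole organism with Mus musculus as the target (a higher number here means that more compound is needed for the effect, a lower number that less compound is needed), are these
- compound 1 `CC1(C)Cc2cc(N)ccc2O1` gives > 100 mg/kg which is a limit of the assay and not a number
- compound 2 `Cc1c(C)c2c(c(C)c1N)CC(C)(CSc1ccccc1)O2` gives 24.7 mg/kg as a measured number

Going by the values given here, compound 2 holds the only true number so far, since the other entry is the limit reached by compound 1. The next molecule keeps everything in compound 2 except one group. The change piperidin-1-yl in place of phenylsulfanyl on a saturated chain carbon bound to a saturated ring carbon puts piperidin-1-yl in place of phenylsulfanyl on a saturated chain carbon bound to a saturated ring carbon, and the result is compound 3 `Cc1c(C)c2c(c(C)c1N)CC(C)(CN1CCCCC1)O2` as the molecule still to be tested. Among the compounds with values here, no measured pair differs by this swap, so the data give no size or direction for it. Within the data shown here, the best guide is compound 2 at 24.7 mg/kg as the single number available. The expected move a 1.2-fold higher number from compound 2 to compound 3 (0.08 log units; within the scatter) is therefore estimated to stay within the usual scatter. Compound 3 is expected at 30 mg/kg with an estimated range from 10 mg/kg to 90 mg/kg in this first test.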

Compound 3, dose for 50% inhibition: 11.7 mg/kg
The estimate for compound 3 lay 2.6-fold (0.41 log units) above the measured number, within the range that was stated.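

In this assay, going by these compounds alone, the step of a 2.1-fold lower number from compound 2 to compound 3 (0.32 log units; beyond the scatter) is the first measured sign that the group on this saturated chain carbon bound to a saturated ring carbon matters, and the step is modest but beyond the usual scatter. Less compound is needed for the effect when the group at this place is piperidin-1-yl rather than phenylsulfanyl, so an aromatic ring of carbon only is not required here for activity in the mouse. Compound 1 alone stands at a limit of the assay and not at a number, differs from the others in more than one place, and leaves this step untouched: the limit of > 100 mg/kg in this assay, at which 1 of the 3 values shown sits.

A single pair cannot tell whether the lower number belongs to piperidin-1-yl itself or would appear with other groups at this place, and it gives no reason for the step. Morpholin-4-yl, a dimethylamino group, or a longer chain carrying the piperidine ring would show how far this trend extends.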